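Hydroxypentyl in Place of the Chlorinated Trifluoromethylphenyl Group

A few compounds are considered here, and "the series" means these few. Any claim that something is new, unique, unknown or untested is made for them only; others in the source may bear on it.

Measured so far:
compound 1, `CCOC(=O)NC(c1ccccc1)c1ccc(Cl)cc1`: > 100000 nM
compound 2, `COc1cc(NC(C)CCCNC(=O)NNC(=O)Nc2ccc(Cl)c(C(F)(F)F)c2)c2ncccc2c1`: 13000 nM

Both compounds were tested in a functional assay on NCI-H460 cells (Homo sapiens) for inhibition, read by MTT assay, with a stated time of 4 days; on this read-out lower numbers stand for stronger inhibition and higher numbers for weaker inhibition. Compound 1 reaches only > 100000 nM, and that reading is a limit of the assay rather than a number; it is the limit of > 100000 nM in this assay, at which 1 of the 2 values shown sits. Within the data shown here, compound 2 gives 13000 nM in this assay, the only true number among the two values shown. Among the measured compounds shown here, no step between two measured compounds that differ in a single place is available, so the size of any change along this series cannot yet be read from measurement.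

Compound 3 `COc1cc(NC(C)CCCNC(=O)NNC(=O)NCCCCCO)c2ncccc2c1` differs from compound 2 in one place: 5-hydroxypentyl in place of 4-chloro-3-(trifluoromethyl)phenyl on an amide-type nitrogen. For the measured compounds named here, with no measured step to lean on, the expectation rests on compound 2 alone, whose value of 13000 nM is already weak. The step is expected to be a 3.1-fold higher number from compound 2 to compound 3 (0.49 log units; beyond the scatter), a weakening beyond the usual scatter, with a real chance that only a limit is reported. Compound 3 is therefore estimated at 40000 nM, within a range from 8000 nM to 150000 nM.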

Compound 3, half-maximal inhibitory concentration: > 100000 nM
Compound 3: no number, only a limit; the forecaster's own chance of this, stated with the estimate: 35%; at least 2.5-fold (0.39 log units) between middle value and limit.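

Among these compounds, the exchange of 4-chloro-3-(trifluoromethyl)phenyl for 5-hydroxypentyl on the amide-type nitrogen gives, in this assay, an at least 7.6-fold higher number from compound 2 to compound 3 (0.88 log units; beyond the scatter), the first step that can be read from measurement. It shows that the group at this place matters: the modest inhibition of compound 2 does not survive when an open chain ending in a hydroxyl takes the place of the substituted aromatic ring. The reading for compound 3 is a limit and not a number, so the full size of the loss stays unknown and the step gives only its smallest possible size: the limit of > 100000 nM in this assay, at which 2 of the 3 values shown sit.

The compounds shown do not separate the parts of this change, since the ring, the chlorine, the trifluoromethyl and the hydroxyl all differ at once between the two compounds. On these data alone, a plain phenyl, a 4-chlorophenyl or an unsubstituted pentyl chain on the same nitrogen would tell these parts apart, and whether any group here can improve on compound 2 at 13000 nM remains open.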